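A Second Fluorine on the Benzyl Arm

A few compounds are considered here, and "the series" means these few. Any claim that something is new, unique, unknown or untested is made for them only; others in the source may bear on it.

Compound 1, `CCSc1nnc(COc2cc(C)c3c(C)cc(=O)oc3c2)o1`: in a functional assay on MDA-MB-231 cells (Homo sapiens) for antiproliferative activity, read by MTT assay, with a stated time of 24 h (on this read-out higher numbers stand for weaker inhibition and lower numbers for stronger inhibition), compound 1 gives > 100000 nM, which is a limit of the assay and not a number.
Compound 2, `Cc1cc(OCc2nnc(SCc3cccc(F)c3)o2)cc2oc(=O)cc(C)c12`: in this assay compound 2 gives > 100000 nM, which is again a limit of the assay and not a number.

The two measured compounds share one core and differ only in the group on the saturated chain carbon bound to sulfur. The step that the two limits leave unreadable from compound 1 to compound 2 cannot be read, since both ends of it are limits. For the measured compounds named here, compound 2 thus stands at the limit, together with the only other value: the limit of > 100000 nM in this assay, at which 2 of the 2 values shown sit.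

Compound 3, `Cc1cc(OCc2nnc(SCc3ccc(F)c(F)c3)o2)cc2oc(=O)cc(C)c12`, has not been measured. Its change from compound 2 is fluoro in place of hydrogen on an aromatic carbon. Going by the values given here, no measured step bears on adding a fluoro to this ring; the single measured step is unreadable and gives no size. With compound 2 at the limit, the expected step that the limit leaves unreadable from compound 2 to compound 3 is none beyond the scatter, and compound 3 is estimated most likely to remain at or near the limit. The estimate for compound 3 in this assay is 150000 nM, with a range from 40000 nM to 600000 nM.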

Compound 3, half-maximal inhibitory concentration: > 100000 nM
Compound 3: no number, only a limit; the forecaster's own chance of this, stated with the estimate: 80%; the middle value is on the limit's open side.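

Compound 3, like compound 1 and compound 2, ends at a limit of the assay and not at a number, so no step among these three compounds can be read: the limit of > 100000 nM in this assay, at which 3 of the 3 values shown sit.

What the compounds shown leave open is whether any change on the benzyl arm or the shared core can bring a measurable value in this assay.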